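Changing the Amine on the Free Hydroxyl Analog

This account rests on a few compounds, and the source may have more. Where it says the series, first, only, none or still open, it means among the compounds named here.

Measured compounds:
Compound 1, `CCCCCCCCCCCCCC[C@H](OCOC)[C@H](CN(CC)CC)NC(=O)OC(C)(C)C`, gives 46.2% in a functional assay on DLD-1 cells (Homo sapiens) for antiproliferative activity, read by sulforhodamine B assay, with a stated time of 48 h, tested at 10 uM; on this read-out higher numbers stand for more inhibition at the one concentration tested (going by the name of the read-out) and lower numbers for less inhibition.
Compound 2, `CCCCCCCCCCCCCC[C@H](OCOC)[C@H](CN(C(C)C)C(C)C)NC(=O)OC(C)(C)C`, gives 53.9% in this assay.
Compound 3, `CCCCCCCCCCCCCC[C@H](O)[C@H](CN(CC)CC)NC(=O)OC(C)(C)C`, gives 14.7% in this assay.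

Compound 3 holds the lowest of the three numbers. Within the data shown here, the only change that separates it from compound 1 is hydrogen in place of methoxymethyl on an oxygen on a saturated carbon, and that step was a number 31.5 percentage points lower from compound 1 to compound 3 (beyond the scatter). Among the measured compounds shown here, compound 2 stands further away still, which the two values show directly; no single step links compound 2 and compound 3.

Compound 4, `CCCCCCCCCCCCCC[C@H](O)[C@H](CN(C(C)C)C(C)C)NC(=O)OC(C)(C)C`, is the next compound to be measured. It differs from compound 3 as follows:

diisopropylamino in place of diethylamino on a saturated chain carbon, two bonds along the chain from an amide-type nitrogen

The same change has been measured once before, between compound 1 and compound 2, both of which carry the methoxymethyl group: that step was a number 7.7 percentage points higher from compound 1 to compound 2 (within the scatter). Nothing else measured bears on this change. On that basis the step to compound 4 is expected to be a number 5.3 percentage points higher from compound 3 to compound 4 (within the scatter), that is, no change beyond the scatter in this assay, with a slight lean upward only because of a number 7.7 percentage points higher from compound 1 to compound 2 (within the scatter). Compound 4 is therefore estimated at 20%, with a range from 6% to 36%.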

Compound 4, a percentage reported as inhibition, at one concentration (the size of the read-out at that concentration, not a potency): 34.8%
Beside the measured number, compound 4's estimate is 14.8 percentage points below it; the range from low to high includes it.
By their numbers in this assay, from the lowest: compound 3; then compound 4; then compounds 1 and 2 (each within the scatter of the next).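

With a free hydroxyl on the shared core, diisopropylamino in place of diethylamino now makes a step that can be told apart from ordinary scatter in this assay, namely a number 20.1 percentage points higher from compound 3 to compound 4 (beyond the scatter). This does not mean that the change behaves differently on the two cores, since the gap between its two readings is itself small enough to be scatter: the same change on two cores in this assay, a number 7.7 percentage points higher (within the scatter) from compound 1 to compound 2 and a number 20.1 percentage points higher (beyond the scatter) from compound 3 to compound 4, 12.4 percentage points apart, within the scatter of two such steps
The other change also holds with the second amine, as hydrogen in place of methoxymethyl on the oxygen again lowers the number, giving a number 19.1 percentage points lower from compound 2 to compound 4 (beyond the scatter), so the drop is now seen with both diethylamino and diisopropylamino: the same change on two cores in this assay, a number 31.5 percentage points lower (beyond the scatter) from compound 1 to compound 3 and a number 19.1 percentage points lower (beyond the scatter) from compound 2 to compound 4, 12.4 percentage points apart, within the scatter of two such steps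

From the compounds shown here alone, only these two open-chain amines and these two forms of the oxygen appear here, so it remains open how a ring amine such as piperidine or morpholine, or a smaller one such as dimethylamino, would read in this assay, and whether a methyl or acetyl group on that oxygen would act like methoxymethyl. Each number also comes from a single concentration in one cell line, and so it gives no measure of potency.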